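The source may report more compounds than this note shows. Statements on the series, on what has been measured and on what is new or still open speak of the compounds shown alone.

Among the compounds with values here, in a functional assay on cells (Burkitts lymphoma cell, Homo sapiens) for antiproliferative activity, read by MTT assay (a lower number here means a stronger inhibitor, a higher number a weaker inhibitor), compound 1 `CC/C(=N\Nc1nc2ccccc2o1)c1ccccn1` gives 2 nM, the only exact number so far. Compound 2 `C/C(=N\N(C)c1nc2ccccc2o1)c1ccccn1` is recorded at > 50000 nM, which is a limit of the assay and not a number. Compound 3 `CC(C)(C)/C(=N\Nc1nc2ccccc2o1)c1ccccn1` has not yet been measured. It keeps the core of compound 1 with one change: tert-butyl in place of ethyl on a carbon with a double bond to nitrogen. Within the data shown here, no measured step shows what such a change does in this assay, so the expectation is a judgement. With compound 1 at 2 nM, there is far more room to lose strength than to gain it, and a weakening beyond the scatter is expected. The expected shift is a 15-fold higher number from compound 1 to compound 3 (1.18 log units; beyond the scatter), towards weaker inhibition. For compound 3 the estimated value is 30 nM, with an expected range from 3 nM to 500 nM.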

Compound 3, half-maximal inhibitory concentration: > 10000 nM
Compound 3 was reported as a limit (the forecaster's own chance of this, stated with the estimate: 5%); middle value at least 330-fold (2.52 log units) away from the limit.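

In this assay, the carbon with a double bond to nitrogen, whose other neighbours are an aromatic carbon and a double-bonded nitrogen, does not accept every group: tert-butyl in place of ethyl there gives an at least 5000-fold higher number from compound 1 to compound 3 (3.69 log units; beyond the scatter). The reading for compound 3 is a limit of the assay and not a number: the limit of > 10000 nM in this assay, at which 1 of the 3 values shown sits. This is the first single-place step shown at this carbon, and it shows that the strength of compound 1 depends on the group held there, while the full size of the loss stays hidden behind the limit.

The compounds shown leave open how an isopropyl or a cyclopropyl group would behave at this carbon, and so whether the loss sets in gradually between ethyl and tert-butyl. They also leave open whether a longer chain such as n-propyl would keep the strength of compound 1.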